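Benzimidazolylmethyl in place of a benzoate on the piperidine nitrogen

A few compounds are considered here, and "the series" means these few. Any claim that something is new, unique, unknown or untested is made for them only; others in the source may bear on it.

Measured compounds:
compound 1 `COC(=O)c1ccc(CN2CCC[C@H](O[C@H](CO)c3cc(Cl)cc(Cl)c3)[C@@H]2c2ccccc2)c(C)c1`: > 200000 nM
compound 2 `Cc1cc(C(=O)O)ccc1C(C)N1CCC[C@H](O[C@H](CO)c2cc(Cl)cc(Cl)c2)[C@@H]1c1ccccc1`: "nd" (no result reported)

In an assay on isolated protein for activation of cGMP-dependent protein kinase 1 (Homo sapiens), read by ADP-Glo, with stated times of 30 min and 2 h (on this read-out higher numbers stand for an effect only at larger amounts of compound and lower numbers for an effect already at smaller amounts), compound 1 reaches only a limit of the assay, > 200000 nM, as noted in the limit of > 200000 nM in this assay, at which 1 of the 2 values shown sits. For compound 2 this assay gives no result at all, so compound 2 stands on no number here. Compound 3 `OC[C@@H](O[C@H]1CCCN(Cc2nc3ccccc3[nH]2)[C@H]1c1ccccc1)c1cc(Cl)cc(Cl)c1` differs from compound 2 by a group of 10 heavy atoms (8 carbon, 2 nitrogen; one five-membered aromatic ring with 2 hetero atoms, one six-membered aromatic ring of carbon only) in place of a group of 12 heavy atoms (10 carbon, 2 oxygen; one six-membered aromatic ring of carbon only), on an amine nitrogen in a ring. Among the measured compounds shown here, with no measured step to lean on, no direction or size of change beyond the scatter can be claimed. Compound 3 is expected to sit near 200000 nM, within 20000 nM to 1000000 nM, most likely again as a limit.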

Compound 3, half-maximal effective concentration: > 200000 nM
Compound 3: a limit, no number (the forecaster's own chance of this, stated with the estimate: 70%); the middle value sits exactly at the limit.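

Among the compounds shown here, compound 1 and compound 3 each give only a limit, not a number, so no step between them can be read. The compounds shown leave open whether the (1H-benzimidazol-2-yl)methyl group changes the read-out at all.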